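Fluoro for Hydrogen on the Dimethoxy-Styryl Ring

This account rests on a few compounds, and the source may have more. Where it says the series, first, only, none or still open, it means among the compounds named here.

Measured so far:
compound 1 `COc1cc(OC)c(/C=C/S(=O)(=O)Cc2ccc(C#N)cc2)c(OC)c1` gives 7500 nM
compound 2 `COc1ccc(CS(=O)(=O)/C=C/c2ccccc2OC)cc1` gives 3500 nM
compound 3 `COc1ccc(CS(=O)(=O)/C=C/c2c(OC)cccc2OC)cc1` gives 250 nM

In a functional assay on DU-145 cells (Homo sapiens) for antiproliferative activity, read by trypan blue exclusion (a higher number here means a weaker inhibitor, a lower number a stronger inhibitor), compound 3 has the lowest number of the three. Among the compounds with values here, its nearest neighbour is compound 2, and the step of a 14-fold lower number from compound 2 to compound 3 (1.15 log units; beyond the scatter) is the only single-point change measured here. Compound 1 stands furthest away.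

Compound 4 `COc1ccc(CS(=O)(=O)/C=C/c2c(OC)cc(F)cc2OC)cc1` differs from compound 3 by fluoro in place of hydrogen on an aromatic carbon. Within the data shown here, no measured step tests a fluoro substitution, and the methoxy step from compound 2 to compound 3 does not bear on it. With nothing to point either way, the number for compound 4 is expected to stay close to that of compound 3, a step of no change at the digits printed from compound 3 to compound 4 (within the scatter) within the scatter. Compound 4 is estimated at 250 nM, in the range 80 nM to 800 nM.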

Compound 4, half-maximal inhibitory concentration: 500 nM
Compound 4: middle estimate off by 2.0-fold (0.30 log units), on the low side; measured number inside the range.
By their numbers in this assay, from the lowest: compounds 3 and 4 (each within the scatter of the next); then compound 2; then compound 1.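

In this assay, fluoro in place of hydrogen on the aromatic carbon para to a large group and meta to two methoxy groups gives a 2.0-fold higher number from compound 3 to compound 4 (0.30 log units; within the scatter). This carbon of the styryl ring therefore accepts a single fluorine without a step beyond the scatter, the first evidence on this position among these compounds. No evidence at hand bears on this result.

As far as these compounds go, whether an amine, a carboxylic acid or a longer chain on this same carbon would keep the number within the scatter of compound 3 remains open. So does whether fluoro would behave the same way on the other aromatic ring.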